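The source may hold more compounds than are shown below. What is called first, only, known or untested is meant among the compounds shown, and "the series" means these compounds.

Measured so far in a functional assay on SEM cells (Homo sapiens) for cytotoxicity, with a stated time of 72 h; on this read-out higher numbers stand for an effect only at larger amounts of compound and lower numbers for an effect already at smaller amounts:
- compound 1 `C=C[C@@](C)(/C=C/c1ccc(O)cc1)CC/C=C/C(=O)c1ccccc1`: > 36600 nM
- compound 2 `C=C[C@@](C)(/C=C/c1ccc(O)cc1)CC/C=C(C)/C=C/C(=O)OCc1ccccc1`: > 36600 nM
- compound 3 `C=C[C@@](C)(/C=C/c1ccc(O)c(/C=C/C(=O)OCC)c1)CCC=C(C)C`: > 36600 nM

All three entries are limits of the assay and not numbers. Compound 3 gives only a limit, > 36600 nM. It has no numerical place in the series, and no order can be read among the three compounds: the limit of > 36600 nM in this assay, at which 3 of the 3 values shown sit.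

Compound 4 `C=C[C@@](C)(/C=C/c1ccc(O)c(/C=C/c2ccc(Cl)cc2)c1)CCC=C(C)C` differs from compound 3 in one place: 4-chlorophenyl in place of ethoxycarbonyl on a double-bonded chain carbon bound to a double-bonded chain carbon. Here 4-chlorophenyl stands in place of ethoxycarbonyl on a double-bonded chain carbon bound to a double-bonded chain carbon, so that 2-(ethoxycarbonyl)ethenyl becomes 2-(4-chlorophenyl)ethenyl.

For the measured compounds named here, no measured pair gives a step with which to scale this change, so the expectation is loose. A modest shift towards lower numbers in this assay is expected, and the estimated step is an at least 1.8-fold lower number from compound 3 to compound 4 (0.26 log units; that floor lies within the scatter). A further limit reading remains quite possible. For compound 4 the expected value is 20000 nM, with an estimated range of 6000 nM to 36600 nM.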

Compound 4, half-maximal effective concentration: > 36600 nM
Compound 4 ended at the assay's limit; the forecaster's own chance of this, stated with the estimate: 55%; middle value at least 1.8-fold (0.26 log units) away from the limit.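

No step can be read from compound 3 to compound 4, as both entries are limits and not numbers in this assay: the limit of > 36600 nM in this assay, at which 4 of the 4 values shown sit.

The compounds shown leave open whether any change to the shared core gives a numerical value in this assay, and how compound 1, compound 2, compound 3 and compound 4 would rank.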